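The source may report more compounds than this note shows. Statements on the series, on what has been measured and on what is new or still open speak of the compounds shown alone.

Compound 1 `Cc1nc2nc(SCc3ccc(Cl)cc3)nn2c(N2CC[C@@H](C)[C@@H](N(C)c3ncnc4[nH]ccc34)C2)c1C` is one of two compounds examined in a functional assay on HGC-27 cells (Homo sapiens) for inhibition, read by MTT assay, with a stated time of 72 h; a higher number here means a weaker inhibitor, a lower number a stronger inhibitor. In this assay compound 1 gives only a limit, > 100000 nM. Compound 2 `Cc1cc(N2CC[C@@H](C)[C@@H](N(C)c3ncnc4[nH]ccc34)C2)n2nc(SCc3csc4ccc(Cl)cc34)nc2n1` shares the same core and differs in the group carried through the sulfur. In this assay compound 2 likewise gives only a limit, > 100000 nM. Both readings therefore sit at the limit of > 100000 nM in this assay, at which 2 of the 2 values shown sit, and compound 2 stands at that limit with no number by which to set it against compound 1. Going by the values given here, no step between measured compounds can be stated. Compound 3 `Cc1cc(N2CC[C@@H](C)[C@@H](N(C)c3ncnc4[nH]ccc34)C2)n2nc(SCc3cc(Cl)ccc3Cl)nc2n1` is not yet measured. It differs from compound 2 by 2,5-dichlorophenyl in place of 5-chloro-1-benzothiophen-3-yl on a saturated chain carbon bound to a sulfur. Because both compound 1 and compound 2 sit at the limit of > 100000 nM in this assay, at which 2 of the 2 values shown sit, nothing here indicates that the group on the saturated chain carbon bound to the sulfur moves the reading off the limit. Compound 3 is therefore expected to remain at the limit, and the step of a number no higher from compound 2 to compound 3 (the limit leaves the size open) is expected to amount to nothing beyond the scatter. For compound 3 the estimate in this assay is 100000 nM, with a range from 30000 nM to 300000 nM.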

Compound 3, half-maximal inhibitory concentration: 19200 nM
Compound 3: middle estimate off by 5.2-fold (0.72 log units), on the high side; the measured number lies below the stated range.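

In this assay, the group on the saturated chain carbon bound to a sulfur turns out to be able to move the reading off the limit: 2,5-dichlorophenyl in place of 5-chloro-1-benzothiophen-3-yl gives an at least 5.2-fold lower number from compound 2 to compound 3 (0.71 log units; beyond the scatter). The earlier compounds could not show this, since neither gave a number, and compound 3 now provides the only true value in the set, while the limit still accounts for most of what is shown: the limit of > 100000 nM in this assay, at which 2 of the 3 values shown sit. The size of the step remains open-ended, so this change is shown to matter at this place, but not by how much, and the result rests on a single pair of compounds.

The change removes the five-membered aromatic ring and adds a second chlorine in one move, so the compounds shown cannot tell which of the two lies behind the step. Going by these compounds, how an unsubstituted benzyl, a methoxybenzyl or a benzyl carrying a nitrile would read at this place on the same core stays open, as does whether any such group would go further than 2,5-dichlorobenzyl.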